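Carbamate chain length on the core of compound 1

The source may report more compounds than this note shows. Statements on the series, on what has been measured and on what is new or still open speak of the compounds shown alone.

The set comprises three measured compounds and one not yet measured. Compound 1 `C=CCOC(=O)Nc1ccc([Se]C#N)cc1` carries an allyl carbamate on its core. In a functional assay on HTB-54 cells (Homo sapiens) for cytotoxicity, read by MTT assay, with a stated time of 72 h (a lower number here means a stronger inhibitor of growth, a higher number a weaker inhibitor of growth), compound 1 gives 50100 nM. Compound 2 `CCCCOC(=O)Nc1ccc([Se][Se]c2ccc(NC(=O)OCCCC)cc2)cc1` is built on a different core; in this assay compound 2 gives 57300 nM. Compound 3 `O=C(Nc1ccc([Se][Se]c2ccc(NC(=O)Oc3ccccc3)cc2)cc1)Oc1ccccc1` shares the core of compound 2 with phenyl carbamate arms, and in this assay compound 3 gives 56200 nM. No pair among these three differs in a single place, so no single-change step can be read from them. Compound 1 sits level with compound 3 and with compound 2; each of those gaps lies within the scatter, so no order among the three can be claimed from these numbers.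

Compound 4 `CCCCCCOC(=O)Nc1ccc([Se]C#N)cc1` keeps the core and the carbamate of compound 1 and differs only at the chain: pentyl in place of vinyl on a saturated chain carbon bound to an oxygen next to a carbonyl group. Cut one bond further out, the same change reads allyl to hexyl. Among the measured compounds shown here, nothing among the measured compounds isolates the effect of chain length on this core, and the three numbers that exist fall together. The step in this assay is therefore expected to be small, in no fixed direction, and not clearly beyond the scatter: a 1.1-fold lower number from compound 1 to compound 4 (0.05 log units; within the scatter). Compound 4 is accordingly estimated at 45000 nM, with a range from 20000 nM to 100000 nM.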

Compound 4, concentration for total growth inhibition: 48500 nM
For compound 4 the middle estimate is 1.1-fold (0.03 log units) below the measured one; the measured number falls inside the stated range.
By their numbers in this assay, from the lowest: compounds 4, 1, 3 and 2 (each within the scatter of the next).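

In this assay, among the compounds shown here, pentyl in place of vinyl on a saturated chain carbon bound to an oxygen next to a carbonyl group gives a 1.0-fold lower number from compound 1 to compound 4 (0.01 log units; within the scatter), the first step that isolates a single change. On the core of compound 1, this position therefore accepts the exchange of allyl for hexyl, with its longer saturated chain and without the double bond outside aromatic rings, while compound 1 and compound 4 stand level within the scatter, so neither chain can be ranked above the other. No measurement is available that bears on the reason for this level result.

On these data alone, whether this position stays equally flat for other groups remains open: an amine or a carboxylic acid at the chain end, a chain longer than hexyl, or a phenyl carbamate on the core of compound 1 could each test it. Compound 2 and compound 3 differ from compound 1 and compound 4 in more than one place, so those steps cannot be read, and the contribution of the core to the read-out stays undetermined.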